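Bromo in place of methylcarbamoyl on the benzylamine ring

This account rests on a few compounds, and the source may have more. Where it says the series, first, only, none or still open, it means among the compounds named here.

Compound 1 `FC(F)(F)c1cc(NCC2CNC2)c2cn[nH]c2c1` gives > 100000 nM in an assay for inhibition of Tryptophan 2,3-dioxygenase (Homo sapiens), with stated times of 10 min and 60 min (a higher number here means a weaker inhibitor, a lower number a stronger inhibitor), a limit of the assay.
Compound 2 `OC1CCCC(Nc2cccc(CNc3cc(C(F)(F)F)cc4[nH]ncc34)c2)C1` gives > 100000 nM in this assay, again a limit.
Compound 3 `CNC(=O)c1cccc(CNc2cc(C(F)(F)F)cc3[nH]ncc23)c1` gives 4870 nM in this assay.

Going by the values given here, compound 3 therefore holds the only real number; the other two results sit at a limit (the limit of > 100000 nM in this assay, at which 2 of the 3 values shown sit). Compound 4 `FC(F)(F)c1cc(NCc2cccc(Br)c2)c2cn[nH]c2c1` differs from compound 3 by bromo in place of methylcarbamoyl on an aromatic carbon. Among the compounds with values here, only one measured step touches this position: an at least 20-fold lower number from compound 2 to compound 3 (1.31 log units; beyond the scatter), a large move, but one that starts from a limit and replaces a different group, so it gives no clear direction for the bromo substituent. The step from compound 3 to compound 4 is thus expected to be modest, a 1.6-fold higher number from compound 3 to compound 4 (0.22 log units; within the scatter). Compound 4 is estimated at 8000 nM, in the range 2000 nM to 40000 nM.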

Compound 4, half-maximal inhibitory concentration: 19100 nM
For compound 4 the middle estimate is 2.4-fold (0.38 log units) below the measured one; the range from low to high includes it.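

In this assay, bromo in place of methylcarbamoyl gives a 3.9-fold higher number from compound 3 to compound 4 (0.59 log units; beyond the scatter), so a measurable number at this aromatic carbon does not depend on the methylcarbamoyl group, although compound 3 remains the stronger inhibitor. Against the other two compounds, the bromo compound still reads lower, with an at least 5.2-fold lower number from compound 2 to compound 4 (0.71 log units; beyond the scatter) and an at least 5.2-fold lower number from compound 1 to compound 4 (0.71 log units; beyond the scatter). Both of these steps start from a limit and give only a bound: the limit of > 100000 nM in this assay, at which 2 of the 4 values shown sit.

As far as these compounds go, whether an amine or a carboxylic acid on this carbon would match compound 3 stays open. The compounds shown also do not separate the carbonyl from the amide hydrogen of methylcarbamoyl as the part that matters.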